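Phenyl to 2-chlorophenyl: the step from compound 3 to compound 4

The source may hold more compounds than are shown below. What is called first, only, known or untested is meant among the compounds shown, and "the series" means these compounds.

Compound 3 `O=C(O)CS(=O)(=O)c1ccc(OCc2cccc(-c3ccccc3)c2)cc1` gives 288 nM in a functional assay on CHO cells for agonist activity at Free fatty acid receptor 1 (Homo sapiens), read by FLIPR and calcium flux (on this read-out lower numbers stand for an effect already at smaller amounts and higher numbers for an effect only at larger amounts of compound), the highest of the two numbers in hand; the nearest is compound 2 `Cc1ccccc1-c1cccc(COc2ccc(S(=O)(=O)CC(=O)O)cc2)c1` with 46.8 nM. Compound 1 `CO/N=C1\CC(CC(=O)O)c2ccc(OCc3cccc(-c4c(C)cc(OC)cc4C)c3)cc21` reports only a limit, > 1000 nM, in this assay (the limit of > 1000 nM in this assay, at which 1 of the 3 values shown sits). Compound 4 `O=C(O)CS(=O)(=O)c1ccc(OCc2cccc(-c3ccccc3Cl)c2)cc1` differs from compound 3 by chloro in place of hydrogen on an aromatic carbon; cut one bond further out the change reads phenyl to 2-chlorophenyl. For the measured compounds named here, the single measured step at this place, a 6.2-fold higher number from compound 2 to compound 3 (0.79 log units; beyond the scatter), shows the position responsive: removing the methyl raised the number beyond the scatter. Putting chloro there is therefore expected to move the number back down, by roughly a 4.1-fold lower number from compound 3 to compound 4 (0.61 log units; beyond the scatter). Compound 4 is estimated at 70 nM, within 25 nM to 200 nM.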

Compound 4, half-maximal effective concentration: 28.8 nM
Estimate against measurement, compound 4: 2.4-fold (0.39 log units) above; measured number inside the range.
By their numbers in this assay, from the lowest: compounds 4 and 2 (each within the scatter of the next); then compound 3. At a limit, above all of these: compound 1.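

In this assay, chloro in place of hydrogen gives a 10-fold lower number from compound 3 to compound 4 (1.00 log units; beyond the scatter), so the response at this position is not confined to methyl. Chloro in place of methyl gives a 1.6-fold lower number from compound 2 to compound 4 (0.21 log units; within the scatter), so these two groups are not separated here. Both substituents sit on the same aromatic carbon, and the unsubstituted phenyl of compound 3 stands apart from both.

The data shown give no reason for either step. On these data alone, whether methoxy, trifluoromethyl or nitrile at this place would match chloro and methyl remains open.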